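What one methyl might do to compound 1

This account rests on a few compounds, and the source may have more. Where it says the series, first, only, none or still open, it means among the compounds named here.

compound 1 `COC(=O)Nc1cc(-c2ccc(OC[C@@](C)(N)CC(C)C)nc2)ccn1` gives 100%
compound 2 `COC(=O)Nc1cc(-c2cnc(OC[C@@](C)(N)CC(C)C)c(C#N)c2)ccn1` gives 95%
compound 3 `COC(=O)Nc1cc(-c2cnc(OC[C@@](C)(N)CC(C)C)c(OC)c2)ccn1` gives 86%

In an ADME assay on microsomes from liver (Homo sapiens) for metabolic stability, read by LC-MS, using NADPH, with a stated time of 10 min, tested at 0.5 uM (on this read-out higher numbers stand for a more stable compound and lower numbers for a less stable compound), compound 1 gives 100%, which cannot be separated from the number of compound 2 but stands clearly above that of compound 3. Compound 4 `COC(=O)Nc1cc(-c2cnc(OC[C@@](C)(N)CC(C)C)cc2C)ccn1` has not yet been measured. It differs from compound 1 by one small change methyl in place of hydrogen on an aromatic carbon, ortho to a large group and opposite the ring nitrogen.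

Two measured steps also start from compound 1 and swap one of its hydrogens for a new group. With cyano the step is a number 5 percentage points lower from compound 1 to compound 2 (within the scatter), and with methoxy it is a number 14 percentage points lower from compound 1 to compound 3 (beyond the scatter). Among the measured compounds shown here, neither group enters at the place the methyl takes, and no measured compound carries a methyl, so these steps are only a rough guide. With compound 1 at 100% there is little room for a higher number, so a small step down is expected, most likely within the scatter. The expected step is a number 8 percentage points lower from compound 1 to compound 4 (within the scatter). For compound 4 the estimated value in this assay is 92%, with an expected range from 78% to 100%.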

Compound 4, percent of the compound remaining: 98%
Compound 4: middle estimate off by 6 percentage points, on the low side; measured number inside the range.
By their numbers in this assay, from the lowest: compounds 3, 2, 4 and 1 (each within the scatter of the next, the first and the last beyond it).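

In this assay, the step for methyl in place of hydrogen on an aromatic carbon, ortho to a large group and opposite the ring nitrogen, is a number 2 percentage points lower from compound 1 to compound 4 (within the scatter), so the numbers of the two compounds cannot be told apart. Among the compounds shown here, this is the first view of this position and of a methyl group, since the cyano and methoxy groups of the earlier compounds sit elsewhere, and it shows that one added carbon here leaves the percent remaining indistinguishable from that of the parent. Nothing available explains this result or says how the methyl acts at this position.

On these data alone, it remains open whether this position would give a similar result with a longer chain such as ethyl, or with a different kind of group such as an amine or a carboxylic acid, and whether a methyl at the place held by the cyano or methoxy group would behave like this one. Since compound 1 gives 100%, this read-out also leaves little room to show any gain from a change to compound 1.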